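Swapping Cyclohexyl for Chlorophenyl on a Chlorinated Background

The source may hold more compounds than are shown below. What is called first, only, known or untested is meant among the compounds shown, and "the series" means these compounds.

Three related compounds have been tested in a functional assay on T47D cells (Homo sapiens) for inhibition, read by sulforhodamine B assay, with a stated time of 48 h; a lower number here means a stronger inhibitor of growth, a higher number a weaker inhibitor of growth. Compound 1 `CC(=O)OC/C(=C\C1CCCCC1)C(=O)c1ccccc1` gives 22000 nM. Compound 2 `CC(=O)OC/C(=C\c1ccc(Cl)cc1)C(=O)c1ccccc1` gives 5300 nM, and compound 3 `CC(=O)OC/C(=C\C1CCCCC1)C(=O)c1ccc(Cl)cc1` gives 18000 nM. Compound 3 thus stands close to compound 1: the change from compound 1 to compound 3, a chloro in place of hydrogen on an aromatic carbon, gave a 1.2-fold lower number from compound 1 to compound 3 (0.09 log units; within the scatter), so the two values cannot be told apart. Against compound 2, the value of compound 3 is clearly the higher of the two.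

Compound 4 `CC(=O)OC/C(=C\c1ccc(Cl)cc1)C(=O)c1ccc(Cl)cc1` has not been measured. It differs from compound 3 in one place: 4-chlorophenyl in place of cyclohexyl on a double-bonded chain carbon bound to a double-bonded chain carbon. This same exchange has been seen once already, between compound 1 and compound 2, where it gave a 4.2-fold lower number from compound 1 to compound 2 (0.62 log units; beyond the scatter). For the measured compounds named here, the only thing separating that pair from the present one is the chloro on an aromatic carbon that compound 3 carries and compound 1 does not, and that chloro on its own barely moved the number. A downward step of about the same size is therefore expected in this assay, namely a 4.0-fold lower number from compound 3 to compound 4 (0.60 log units; beyond the scatter). Compound 4 is accordingly estimated at 4500 nM, with a likely range from 1800 nM to 11000 nM.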

Compound 4, concentration for 50% growth inhibition: 5400 nM
For compound 4 the middle estimate is 1.2-fold (0.08 log units) below the measured one, and the stated range covers the measured number.
By their numbers in this assay, from the lowest: compounds 2 and 4 (each within the scatter of the next); then compounds 3 and 1 (each within the scatter of the next).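

The exchange of cyclohexyl for 4-chlorophenyl now holds on a second background in this assay, giving a 3.3-fold lower number from compound 3 to compound 4 (0.52 log units; beyond the scatter), so the step no longer rests on a single pair and its size changes little when the other ring carries a chloro: the same change on two cores in this assay, a 4.2-fold lower number (0.62 log units; beyond the scatter) from compound 1 to compound 2 and a 3.3-fold lower number (0.52 log units; beyond the scatter) from compound 3 to compound 4, 1.2-fold (0.10 log units) apart, within the scatter of two such steps. The chloro on an aromatic carbon, which could not be told apart from hydrogen in the cyclohexyl pair, also makes no readable difference when 4-chlorophenyl is present, with a 1.0-fold higher number from compound 2 to compound 4 (0.01 log units; within the scatter): the same change on two cores in this assay, a 1.2-fold lower number (0.09 log units; within the scatter) from compound 1 to compound 3 and a 1.0-fold higher number (0.01 log units; within the scatter) from compound 2 to compound 4, 1.2-fold (0.10 log units) apart, within the scatter of two such steps. Across these four compounds the two changes therefore behave independently, and only the group on the double-bonded chain carbon separates the values, with no compound going against this.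

As far as these compounds go, what remains open is whether the step comes from the aromatic ring itself or from its chlorine, a question that a plain phenyl on that carbon would address. From the compounds shown here alone, it is also open how that position responds to groups of a different kind, such as an amine, a carboxylic acid or a longer chain in place of the ring.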